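The compounds below may be only part of what the source reports. "The series", "measured", "known", "first", "only" and "open" are said of these compounds alone.

Measured so far in a functional assay on SH-SY5Y cells (Homo sapiens) for cytotoxicity, read by MTT assay, with a stated time of 48 h; on this read-out lower numbers stand for stronger inhibition and higher numbers for weaker inhibition:

- compound 1, `CC(c1nccs1)C(C#N)(C#N)CCC(F)=C(F)F`: > 120000 nM
- compound 2, `O=S(=O)(CCC(F)(Cl)C(F)(F)Cl)c1nc2ccccc2s1`: 4500 nM
- compound 3, `FC(F)=C(F)CCSc1nc2ccccc2[nH]1`: > 120000 nM

Of the three compounds, only compound 2 carries a number in this assay, namely 4500 nM. Compound 1 gives only a limit of the assay, > 120000 nM. Compound 3 likewise gives only a limit, > 120000 nM. For the measured compounds named here, two of the three values therefore sit at the limit of > 120000 nM in this assay, at which 2 of the 3 values shown sit, so compound 2 is the only compound among those measured for which a definite half-maximal inhibitory concentration is known, and there is no pair of measured compounds differing in one place from which a step could be read.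

The step that this account follows goes from compound 2 to compound 4, `O=S(=O)(CCC(F)(Cl)C(F)(F)Cl)c1nc2ccc(Cl)cc2s1`. The change is chloro in place of hydrogen on an aromatic carbon. Compound 4 keeps everything else of compound 2 unchanged.

Going by the values given here, with no measured step to lean on, the expectation for compound 4 can rest only on the number for compound 2. A chloro in place of hydrogen on an aromatic carbon of the fused ring is expected to move this assay by no more than the usual scatter, or at most slightly towards a lower number, so the step from compound 2 to compound 4 is estimated as a 1.5-fold lower number from compound 2 to compound 4 (0.18 log units; within the scatter). Compound 4 is therefore expected to give about 3000 nM, within a range from 1200 nM to 10000 nM.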

Compound 4, half-maximal inhibitory concentration: 6000 nM
Beside the measured number, compound 4's estimate is 2.0-fold (0.30 log units) below it; measured number inside the range.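

In this assay the account now has its first step that can be read, and a 1.3-fold higher number from compound 2 to compound 4 (0.12 log units; within the scatter) leaves the two compounds within the usual scatter of each other. For the compounds shown here, this is the first sign of how this position behaves: on an aromatic carbon of the six-membered aromatic ring of carbon only, meta to a fused ring and para to a fused ring, chloro in place of hydrogen produces no change that can be told apart from repeat measurement, and compound 4 still gives a definite number rather than a limit. What lies behind so small a step is not something the data shown can explain.

Steps involving compound 1 or compound 3 cannot be read, so this single step remains the only evidence on a change to the shared core of compound 2 and compound 4. From the compounds shown here alone, what a methoxy group, an amine or a carboxylic acid would do in this same place stays open, as does whether chloro on the other aromatic carbons of that ring, or a longer chain in place of the halogenated chain, would leave the number just as unmoved.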